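Coumarin-3-carboxamide series: methoxy for methyl on the anilide

The source may hold more compounds than are shown below. What is called first, only, known or untested is meant among the compounds shown, and "the series" means these compounds.

Measured so far in an in vitro assay on BTI-TN-5B1-4 cells for inhibition of Amine oxidase [flavin-containing] B (Homo sapiens), read by fluorescence; a higher number here means a weaker inhibitor, a lower number a stronger inhibitor:
compound 1 `O=C(NC1CCCCC1)c1cc2ccccc2oc1=O`: 500 nM
compound 2 `Cc1cccc(NC(=O)c2cc3ccccc3oc2=O)c1`: 600 nM
compound 3 `Cc1ccc(NC(=O)c2cc3ccccc3oc2=O)cc1`: 710 nM

The three amides share one core and differ only in the group on the amide-type nitrogen. In this assay the numbers sit close together: the step of a 1.2-fold higher number from compound 1 to compound 2 (0.08 log units; within the scatter) and the step of a 1.4-fold higher number from compound 1 to compound 3 (0.15 log units; within the scatter) are both within the scatter, as is a 1.2-fold higher number from compound 2 to compound 3 (0.07 log units; within the scatter). Compound 3 therefore cannot be separated from compound 1 or compound 2 on the numbers shown; swapping cyclohexyl for a methylphenyl, or moving the methyl from 3-methylphenyl to 4-methylphenyl, has left no mark beyond the scatter.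

The next compound, compound 4 `COc1ccc(NC(=O)c2cc3ccccc3oc2=O)cc1`, carries the change (methoxy in place of methyl on an aromatic carbon); the new group sits para to a large group. Within the data shown here, no measured step exchanges a methyl for a methoxy, so the only guide is the general flatness of the series across three different nitrogen substituents. On that basis the expected step of a 1.0-fold lower number from compound 3 to compound 4 (0.01 log units; within the scatter) is none beyond the scatter. Compound 4 is accordingly estimated at 700 nM in this assay, with a range from 300 nM to 1600 nM.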

Compound 4, half-maximal inhibitory concentration: 820 nM
Beside the measured number, compound 4's estimate is 1.2-fold (0.07 log units) below it; low and high end bracket the measured number.
By their numbers in this assay, from the lowest: compounds 1, 2, 3 and 4 (each within the scatter of the next).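

On the aromatic carbon para to a large group, methoxy in place of methyl gives a 1.2-fold higher number from compound 3 to compound 4 (0.06 log units; within the scatter) in this assay, so compound 4 cannot be separated from compound 3. The earlier compounds shown here varied the nitrogen substituent or the place of the methyl, whereas this pair changes the group itself at a fixed position. Entry of one more heavy atom, an oxygen counted as a hydrogen-bond acceptor, leaves no mark beyond the scatter at this position, and no supporting data bear on the reason for this result.

Still open, going by these compounds, is whether a carboxylic acid, an amine or a longer chain such as butoxy at this same position would produce a step beyond the scatter. Also open, on these data alone, is how methoxy would compare with methyl at the place the methyl occupies in compound 2.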